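Adding one methoxy group to compound 2

The source may report more compounds than this note shows. Statements on the series, on what has been measured and on what is new or still open speak of the compounds shown alone.

In an ADME assay on CCRF-CEM cells (Homo sapiens) for antiproliferative activity, with a stated time of 48 h (on this read-out lower numbers stand for stronger inhibition and higher numbers for weaker inhibition), compound 1 (`COc1cccc(/C=C/C(=O)c2ccc(N)cc2)c1OC`) gives 7600 nM and compound 2 (`COc1ccc(/C=C/C(=O)c2ccc(N)cc2)c(OC)c1`) gives 18000 nM. Compound 2 therefore holds the higher number of the two, which makes it the weaker inhibitor of this pair, and the gap between them lies beyond the usual scatter.

The next compound is compound 3 (`COc1ccc(/C=C/C(=O)c2ccc(N)cc2)c(OC)c1OC`), which has methoxy in place of hydrogen on an aromatic carbon of compound 2 (methoxy in place of hydrogen on an aromatic carbon). The new group sits on the six-membered aromatic ring of carbon only, ortho to two methoxy groups and meta to a large group.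

Among the compounds with values here, no measured pair isolates a single change, so the data give no direct guide to the size of this step. Within the data shown here, only two values frame the expectation, and both are in the micromolar-scale band set by compound 1 at 7600 nM and compound 2 at 18000 nM. A modest move toward a lower number is expected, one that may not clear the scatter. The estimated change is a 1.8-fold lower number from compound 2 to compound 3 (0.26 log units; within the scatter). For compound 3 the expected value is 10000 nM, with an estimated range of 4000 nM to 25000 nM.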

Compound 3, half-maximal inhibitory concentration: 9700 nM
Compound 3: middle estimate off by 1.0-fold (0.01 log units), on the high side; the measured number falls inside the stated range.
By their numbers in this assay, from the lowest: compounds 1, 3 and 2 (each within the scatter of the next, the first and the last beyond it).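

Within the data shown here, these are the first steps that isolate a single change, and both are the same one: methoxy in place of hydrogen on an aromatic carbon. In this assay the step read from one parent is a 1.9-fold lower number from compound 2 to compound 3 (0.27 log units; within the scatter) and the step read from the other is a 1.3-fold higher number from compound 1 to compound 3 (0.11 log units; within the scatter), so neither step clears the scatter. A third methoxy group at this place, ortho to two methoxy groups and meta to a large group, is therefore tolerated in this read-out, and compound 3 stays in the same micromolar-scale band as its two parents, with no measurable gain or loss from the added group. Nothing available bears on why this step is small.

As far as these compounds go, these two steps test only methoxy on this ring, so what a hydroxyl group, a chlorine atom or a longer alkoxy chain would do at the same carbon stays open. From the compounds shown here alone, it also stays open whether this tolerance would hold if the amine on the shared core gave way to an amide or a carboxylic acid.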